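The source may report more compounds than this note shows. Statements on the series, on what has been measured and on what is new or still open speak of the compounds shown alone.

Working notes on the sugar conjugate series in a physicochemical assay for lipophilicity, using the shake flask method; a lower number here means a more polar compound, a higher number a more lipophilic compound. Compound 1 `CC(=O)N[C@H]1[C@H](OCCN(C)C(=O)Cn2ccnc2[N+](=O)[O-])O[C@H](CO)[C@H](O)[C@@H]1O` returns only a limit in this assay, < 0.01. Compound 2 `CN(CCO[C@@H]1O[C@H](CO)[C@@H](O)[C@H](O)[C@H]1O)C(=O)Cn1ccnc1[N+](=O)[O-]` likewise returns a limit in this assay, < 0.01. Within the data shown here, compound 3 `CC(=O)OC[C@H]1O[C@@H](OCCN(C)C(=O)Cn2ccnc2[N+](=O)[O-])[C@H](OC(C)=O)[C@@H](OC(C)=O)[C@@H]1OC(C)=O` is the one entry with a number in this assay, giving 0.105. Among the measured compounds shown here, the other two entries sit at the limit of < 0.01 in this assay, at which 2 of the 3 values shown sit, so no step between measured compounds can be stated. Compound 4 `CC(=O)OC[C@H]1O[C@H](OCCN(C)C(=O)Cn2ccnc2[N+](=O)[O-])[C@@H](OC(C)=O)[C@@H](OC(C)=O)[C@@H]1OC(C)=O` is not yet measured. It differs from compound 3 as follows: the two compounds have the same atoms and bonds and differ only in configuration as drawn: 2 of 5 stereo elements differ; a stereocentre at a saturated ring carbon is drawn R in compound 3 and S in compound 4; a stereocentre at a saturated ring carbon is drawn R in compound 3 and S in compound 4. For the measured compounds named here, with the same atoms and bonds in both, no step in this assay beyond the usual scatter is expected, in either direction. The step from compound 3 to compound 4 is estimated at a number 0.01 log units lower from compound 3 to compound 4 (within the scatter). Compound 4 is accordingly expected at 0.1 in this assay, within a range from -0.15 to 0.35.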

Compound 4, partition coefficient: 0.0697
Beside the measured number, compound 4's estimate is 0.03 log units above it, within the range that was stated.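

In this assay the series now holds its first step between two numbers, a number 0.04 log units lower from compound 3 to compound 4 (within the scatter). This pair isolates configuration alone, so a change at two stereocentres at saturated ring carbons can be read directly, and here it stays within the scatter: the fact that compounds 3 and 4 differ only in the configuration as drawn. The earlier entries could not show such a step: the limit of < 0.01 in this assay, at which 2 of the 4 values shown sit.

From the compounds shown here alone, whether the same configuration change would stay within the scatter on a sugar with free hydroxyl groups remains open. So does whether a butyryl ester in place of the acetyl esters would give a step beyond the scatter in this assay.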